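The compounds below may be only part of what the source reports. "The series", "measured", "known", "first", "only" and "open" are said of these compounds alone.

In a functional assay on SW982 cells (Homo sapiens) for inhibition, read by MTT assay, with a stated time of 72 h (a lower number here means a stronger inhibitor, a higher number a weaker inhibitor), three compounds gave these values:

compound 1 `COc1cc(OC)c(-c2cc(=O)c3cc(Cl)ccc3o2)cc1OC` - > 150000 nM
compound 2 `COc1cc(OC)c(OC)cc1/C=C/C(=O)c1ccc(O)cc1O` - 32400 nM
compound 3 `COc1cc(C(=O)/C=C/c2cc(OC)c(OC)cc2OC)ccc1O` - > 150000 nM

Compound 2 is the only one of the three with an actual number. Compound 1 reads > 150000 nM and this is a limit of the assay, not a number. Compound 3 reads > 150000 nM and this too is only a limit.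

The next compound, compound 4 `COc1cc(OC)c(OC)cc1/C=C/C(=O)c1ccc(Br)cc1`, has not yet been measured. It places 4-bromophenyl in place of 2,4-dihydroxyphenyl on a carbonyl carbon and is otherwise identical to compound 2. For the measured compounds named here, no measured step shows what this exchange does, so the expectation is loose and rests on compound 2 at 32400 nM as its only numerical anchor. A modest weakening in this assay is expected, and the reading could also reach the limit. The estimated change is a 2.5-fold higher number from compound 2 to compound 4 (0.39 log units; beyond the scatter) as a working figure. Compound 4 is estimated at 80000 nM with an expected range from 25000 nM to 200000 nM in this test.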

Compound 4, half-maximal inhibitory concentration: 38200 nM
Compound 4: the middle estimate sits 2.1-fold (0.32 log units) above what was measured; measured number inside the range.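

In this assay, 4-bromophenyl in place of 2,4-dihydroxyphenyl on a carbonyl carbon gives a 1.2-fold higher number from compound 2 to compound 4 (0.07 log units; within the scatter). For the compounds shown here, this is the first direct look at this place, and the two readings cannot be told apart, even though the entering group carries no hydrogen-bond donors or acceptors, so for this pair a number in this test does not depend on the 2,4-dihydroxyphenyl group. Compound 4, like compound 2, gives an actual number and does not sit at the limit of the test: the limit of > 150000 nM in this assay, at which 2 of the 4 values shown sit.

This single step says nothing about how an amine or a carboxylic acid on the phenyl ring at this carbonyl carbon would read. As far as these compounds go, whether a phenyl ring with no bromine and no hydroxyl groups would read the same also remains open.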